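Ether versus amide side chains on a shared core

A few compounds are considered here, and "the series" means these few. Any claim that something is new, unique, unknown or untested is made for them only; others in the source may bear on it.

Measured so far:
- compound 1 `Cc1nn(-c2ncnc3nc[nH]c23)c2c1C(C(=O)NCc1ccccc1)CC(=O)N2`: in a functional assay on HEK293 cells for agonist activity at G-protein coupled receptor 39 (Homo sapiens), read by scintillation proximity assay and inositol phosphate accumulation, with a stated time of 75 min, in the presence of a further agent that is not named here (on this read-out lower numbers stand for an effect already at smaller amounts and higher numbers for an effect only at larger amounts of compound), compound 1 gives 5 nM
- compound 2 `Cc1nn(-c2ncnc3nc[nH]c23)c2c1C(OCc1ccc(C(C)C)cc1)CC(=O)N2`: in this assay compound 2 gives 5 nM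
- compound 3 `C=CCN1c2c(n(C)c(=O)n(C)c2=O)NC1N/N=C/c1ccc(O)cc1O`: in this assay compound 3 gives 340 nM

Compound 2 sits level with compound 1 at the digits shown, the two together giving the lowest numbers of the three; the difference between them lies within the scatter, so no order can be read between them. Compound 3, which is built on a different core, gives a markedly higher number, and its gap to compound 2 lies beyond the scatter.

Compound 4 `Cc1nn(-c2ncnc3nc[nH]c23)c2c1C(OCc1ccccc1Cl)CC(=O)N2` is not yet measured. It keeps the core of compound 2 and the ether link, and differs in the group at the end of that link: 2-chlorophenyl in place of 4-isopropylphenyl on a saturated chain carbon bound to an oxygen on a saturated carbon

Within the data shown here, no measured pair shows this change on its own, so the step has to be estimated. Compound 1 carries a plain benzyl on an amide and matches compound 2, which argues that the aryl end tolerates some variation. The step from compound 2 to compound 4 is expected to be small, at most a modest rise in this assay, and may well stay within the scatter: a 2.0-fold higher number from compound 2 to compound 4 (0.30 log units; within the scatter).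

For compound 4 the expected value in this assay is 10 nM, with a range from 3 nM to 40 nM.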

Compound 4, half-maximal effective concentration: 2 nM
Compound 4: middle estimate off by 5.0-fold (0.70 log units), on the high side, outside the stated range (below it).
By their numbers in this assay, from the lowest: compound 4; then compounds 1 and 2 (each within the scatter of the next); then compound 3.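

In this assay, the ether side chain keeps a low number when 2-chlorophenyl replaces 4-isopropylphenyl on a saturated chain carbon bound to an oxygen on a saturated carbon, and the modest step is beyond the scatter (a 2.5-fold lower number from compound 2 to compound 4 (0.40 log units; beyond the scatter)). The 4-isopropyl group is therefore not required for a low number on this ether side chain, and the smaller 2-chlorophenyl end, with 7 heavy atoms against 9, does at least as well. The (2-chlorobenzyl)oxy group also separates from the benzylcarbamoyl group on the saturated ring carbon (a 2.5-fold lower number from compound 1 to compound 4 (0.40 log units; beyond the scatter)), so this position now shows a difference beyond the scatter, which compound 1 and compound 2 alone could not show.

No measurement here accounts for either step, and no cause can be assigned to them.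

The swap from compound 2 to compound 4 changes the whole aryl end at once, so the contributions of the chlorine and of the loss of the isopropyl cannot be separated. From the compounds shown here alone, how a plain phenyl, a methoxyphenyl, a pyridyl or an end carrying an amine or a carboxylic acid would fare on the same ether link remains open.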